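The source may report more compounds than this note shows. Statements on the series, on what has been measured and on what is new or still open speak of the compounds shown alone.

In a functional assay on FM3A cells (Mus musculus) for antiproliferative activity (a lower number here means a stronger inhibitor, a higher number a weaker inhibitor), two compounds sharing one core have been measured so far. Compound 1 `COc1cc(C(=O)c2sc(-c3ccncc3)cc2N)cc(OC)c1OC` gives 150 nM, and compound 2 `COc1ccc(-c2cc(N)c(C(=O)c3cc(OC)c(OC)c(OC)c3)s2)cc1` gives 31 nM, the lower of the two numbers. Going by the values given here, the one measured step, a 4.8-fold lower number from compound 1 to compound 2 (0.68 log units; beyond the scatter), puts 4-methoxyphenyl in place of pyridin-4-yl on an aromatic carbon; it is modest but beyond the usual scatter. Compound 3 `COc1cc(C(=O)c2sc(-c3ccc(C(F)(F)F)cc3)cc2N)cc(OC)c1OC` keeps the core of compound 2 and has trifluoromethyl in place of methoxy on an aromatic carbon, para to a large group: trifluoromethyl in place of methoxy on an aromatic carbon. Among the compounds with values here, no measured step covers this exact exchange, so the only guide is the step to the 4-methoxyphenyl compound, a 4.8-fold lower number from compound 1 to compound 2 (0.68 log units; beyond the scatter), which shows that a change in this group can move the number by a modest amount. With methoxy gone, a step of similar or smaller size toward a higher number is expected, although the direction rests on very little data. The expected step is a 2.9-fold higher number from compound 2 to compound 3 (0.46 log units; beyond the scatter). For compound 3 the estimated value is 90 nM, with an expected range from 28 nM to 300 nM.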

Compound 3, half-maximal inhibitory concentration: 540 nM
Beside the measured number, compound 3's estimate is 6.0-fold (0.78 log units) below it; measured number above the stated range.
By their numbers in this assay, from the lowest: compound 2; then compound 1; then compound 3.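

At this position in this assay, the exchange of methoxy for trifluoromethyl, para to a large group, gives a 17-fold higher number from compound 2 to compound 3 (1.24 log units; beyond the scatter) and is a large step, whereas the earlier exchange at the same place, a 4.8-fold lower number from compound 1 to compound 2 (0.68 log units; beyond the scatter), was only modest. The comparison with the pyridin-4-yl compound adds a direction that the first two compounds could not show, since 4-(trifluoromethyl)phenyl in that place gives a 3.6-fold higher number from compound 1 to compound 3 (0.56 log units; beyond the scatter), so the number moves up or down with the group chosen, and among these three groups 4-methoxyphenyl gives the lowest number. No measurement offered here accounts for these differences.

From the compounds shown here alone, whether the low number depends on methoxy itself remains open, as a hydroxy group, an ethoxy group, a methyl group or a chlorine atom in the same place could stay close to compound 2 or move toward compound 3. Going by these compounds, all three compounds also share the same remaining structure, so it is unknown whether the large step would persist with an acetyl group or a methyl group on the amine of the core.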